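Adding a pyrazole to a polar amide

The source may report more compounds than this note shows. Statements on the series, on what has been measured and on what is new or still open speak of the compounds shown alone.

Measured in a physicochemical assay for lipophilicity, read by HPLC, measured as chromatographic lipophilicity, at pH 7.4; a higher number here means a more lipophilic compound, a lower number a more polar compound:
Compound 1 `Cc1ccc(C2CC=NN2C(=O)C(C)(C)C)cc1`: 6.4
Compound 2 `CC(=O)N1CCC(C(=O)N2N=CCC2c2ccccc2)CC1`: 2.5

Of these two numbers, the lower belongs to compound 2 at 2.5. Compound 1 stands at 6.4, higher by a margin well beyond the usual scatter. The next compound to be measured is compound 3 `O=C(c1cn[nH]c1)N1CCC(C(=O)N2N=CCC2c2ccccc2)CC1`. It differs from compound 2 by one change: 1H-pyrazol-4-yl in place of methyl on a carbonyl carbon. In words, this places 1H-pyrazol-4-yl in place of methyl on a carbonyl carbon. For the measured compounds named here, the two measured compounds differ in more than one place, and they offer no direct precedent for this change. The expectation therefore starts from compound 2 at 2.5. In this assay, a small upward move is expected, an estimated a number 0.40 log units higher from compound 2 to compound 3 (beyond the scatter), close to the edge of the scatter. For compound 3, the expected value is 2.9, within an estimated range of 2.4 to 3.4.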

Compound 3, distribution coefficient: 2.1
Beside the measured number, compound 3's estimate is 0.80 log units above it; measured number below the stated range.
By their numbers in this assay, from the lowest: compound 3; then compound 2; then compound 1.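

Placing 1H-pyrazol-4-yl in place of methyl on a carbonyl carbon gives the first direct reading at this position: in this assay the result is a number 0.40 log units lower from compound 2 to compound 3 (beyond the scatter), a modest step. The exchange adds a five-membered aromatic ring with 2 hetero atoms, along with 1 hydrogen-bond donor and 1 hydrogen-bond acceptor, and the number still falls rather than rises. Nothing available here accounts for the direction of this step.

The compounds shown leave open how a phenyl ring or a 1-methyl-1H-pyrazol-4-yl group, which has no ring hydrogen on nitrogen, would read on the same carbonyl carbon. For the compounds shown here, they also leave open whether this step would hold with an amine or a carboxylic acid on that ring, or on a different core, since this single pair is the only direct comparison.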